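Ester-bearing Substituent Replaces Bromo on the Fused Core

The source may hold more compounds than are shown below. What is called first, only, known or untested is meant among the compounds shown, and "the series" means these compounds.

Compound 3 `Cc1nc2c(OCc3ccccc3)cccn2c1Br` stands second highest among three measured numbers in a functional assay on the whole organism with Rattus norvegicus as the target, with a stated time of 4 h, at a dose of 40 mg/kg by the intraperitoneal route (on this read-out higher numbers stand for more inhibition at the one dose given (going by the name of the read-out) and lower numbers for less inhibition), where compound 3 gives 26%. Its nearest neighbour is compound 2 `Cc1nc2c(OCc3ccccc3)cccn2c1C#N`, which in this assay gives 25%; the pair lies within the scatter (a number 1 percentage points higher from compound 2 to compound 3 (within the scatter)). Furthest away is compound 1 `Cc1cn2cccc(OCc3ccccc3)c2n1`, which in this assay gives 62%.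

Compound 4 `CCCCC(=O)OCc1c(C)nc2c(OCc3ccccc3)cccn12` differs from compound 3 in one place: ((butylcarbonyl)oxy)methyl in place of bromo on an aromatic carbon. Within the data shown here, no measured step swaps bromo for ((butylcarbonyl)oxy)methyl, so the nearest guides are the two steps onto the same aromatic carbon, a number 37 percentage points lower from compound 1 to compound 2 (beyond the scatter) and a number 36 percentage points lower from compound 1 to compound 3 (beyond the scatter), both large drops when hydrogen gives way to cyano or bromo, while cyano against bromo moved nothing beyond the scatter. The data therefore suggest that a group on this carbon lowers the read-out, but say nothing about a larger one.

The estimate for compound 4 is a step of a number 4 percentage points higher from compound 3 to compound 4 (within the scatter), within the scatter, and an expected value of 30% with a range from 5% to 60%.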

Compound 4, a percentage reported as inhibition, in the whole organism at one dose (the size of the read-out at that dose, not a potency): 45%
Compound 4: middle estimate off by 15 percentage points, on the low side; the measured number falls inside the stated range.
By their numbers in this assay, from the lowest: compounds 2 and 3 (each within the scatter of the next); then compound 4; then compound 1.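

In this assay, ((butylcarbonyl)oxy)methyl on this aromatic carbon gives a number 19 percentage points higher from compound 3 to compound 4 (beyond the scatter) and a number 20 percentage points higher from compound 2 to compound 4 (beyond the scatter), so a group at this place need not hold the read-out down at the level seen with bromo and cyano. The hydrogen of compound 1 still stands apart, with a number 17 percentage points lower from compound 1 to compound 4 (beyond the scatter), so the new group recovers only part of the earlier drop, and the size of that drop depends on which group enters. Nothing at hand accounts for this difference between the groups.

The compounds shown leave open whether the gain goes with the ester or with the butylcarbonyl chain. From the compounds shown here alone, a hydroxymethyl group, an aminomethyl group or a longer acyl chain on this carbon would test that, and how far the read-out can climb here also remains unknown.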